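Aryl variation in the guanidine-imidazole series: maximal response

A few compounds are considered here, and "the series" means these few. Any claim that something is new, unique, unknown or untested is made for them only; others in the source may bear on it.

Compound 1 `N=C(NCCCc1c[nH]cn1)NCCCC(c1ccccc1)c1ccccn1` in a functional assay on cardiac atrium for agonist activity at histamine H2 receptor (Cavia porcellus) (a lower number here means a smaller maximal response, a higher number a larger maximal response), gives 1.
Compound 2 `N/C(=N\CCC(c1ccc(O)cc1)c1ccccn1)NCCCc1c[nH]cn1` in this assay gives 1.
Compound 3 `N=C(NCCCc1c[nH]cn1)NCCC(c1ccc(Cl)cc1)c1ccccn1` in this assay gives 1.

Compound 3 stands level with compound 1 and compound 2 at the digits shown: all three reach the full response of the reference agonist in this assay, and the differences among them lie within the scatter of the method. Compound 1 carries a phenyl at the chain carbon, compound 2 a 4-hydroxyphenyl, compound 3 a 4-chlorophenyl, and none of these changes shows in the maximal response.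

The next compound, compound 4 `N=C(NCCCc1c[nH]cn1)NCCC(c1cccc(C(F)(F)F)c1)c1ccccn1`, differs from compound 3 in one place:

3-(trifluoromethyl)phenyl in place of 4-chlorophenyl on a saturated chain carbon bound to an aromatic carbon and a saturated chain carbon

For the measured compounds named here, no step between measured compounds is recorded for this kind of exchange. Given that compound 1, compound 2 and compound 3 all give the same maximal response whatever the aryl group at this chain carbon, the expected step in this assay is none beyond the scatter, with a full response again the likeliest outcome. Compound 4 is therefore expected to give 1 in this assay, between 0.85 and 1. The expected step from compound 3 to compound 4 is no change at the digits printed from compound 3 to compound 4 (within the scatter).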

Compound 4, intrinsic activity: the largest response reached, as a fraction of the reference agonist's: 1
Compound 4: middle estimate and measured number agree at the digits printed; measured number inside the range.
By their numbers in this assay, from the lowest: compounds 1, 2, 3 and 4 (each within the scatter of the next).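

In this assay the exchange of 4-chlorophenyl for 3-(trifluoromethyl)phenyl on a saturated chain carbon bound to an aromatic carbon and a saturated chain carbon shows no change at the digits printed from compound 3 to compound 4 (within the scatter) and gives the series its first readable step across a single place. At this position, then, the maximal response does not register a switch from the chlorine-bearing group to a group with more heavy atoms, carbon and fluorine, and with its substituent named at a different ring position, while the counts of hydrogen-bond donors and acceptors and the net charge stay the same for both groups. No measurement here explains this flat result.

From the compounds shown here alone, whether an aryl group carrying a carboxylic acid or a primary amine, or a cyclohexyl group in place of the aryl group, would bring the maximal response down remains open, as all the changes seen so far keep an uncharged aromatic carbon ring at this carbon. The maximal response also leaves open how compound 3 and compound 4 compare in potency, which would need a concentration-based read-out.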